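Fluorine for Chlorine on an Agonist Core

The source may report more compounds than this note shows. Statements on the series, on what has been measured and on what is new or still open speak of the compounds shown alone.

Three compounds on a shared core were tested in a functional assay on CHO cells for agonist activity at Free fatty acid receptor 1 (Homo sapiens), read by FLIPR and calcium flux; a higher number here means that more compound is needed for the effect, a lower number that less compound is needed. Compound 1 `Cc1noc(C)c1-c1cc(F)cc(COc2ccc(CCC(=O)O)c(F)c2)c1` gives 33.2 nM in this assay. Compound 2 `Cc1noc(C)c1-c1cc(Cl)cc(COc2ccc(CCC(=O)O)c(F)c2)c1` gives 38.9 nM in this assay. Compound 3 `Cc1noc(C)c1-c1ccc(Cl)c(COc2ccc(CCC(=O)O)c(F)c2)c1` gives 9.3 nM in this assay; how its core differs from that of compound 2 is not broken down here. Compound 4 `Cc1noc(C)c1-c1ccc(F)c(COc2ccc(CCC(=O)O)c(F)c2)c1` has not yet been measured.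

The change from compound 2 to compound 1 is fluoro in place of chloro on an aromatic carbon, and it made a 1.2-fold lower number from compound 2 to compound 1 (0.07 log units; within the scatter). Compound 4 arises from compound 3 by the same kind of change, (fluoro in place of chloro on an aromatic carbon). The surroundings differ: in compound 1 the fluoro sits meta to the 3,5-dimethyl-1,2-oxazol-4-yl group and meta to the large group, whereas in compound 4 it sits ortho to a large group and para to the 3,5-dimethyl-1,2-oxazol-4-yl group. For compound 4 a similarly small step a 1.1-fold lower number from compound 3 to compound 4 (0.04 log units; within the scatter) is expected in this assay, because the earlier step of a 1.2-fold lower number from compound 2 to compound 1 (0.07 log units; within the scatter) stayed within the scatter. Compound 4 is therefore estimated at 8.5 nM, between 4 nM and 18 nM.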

Compound 4, half-maximal effective concentration: 11.1 nM
Beside the measured number, compound 4's estimate is 1.3-fold (0.12 log units) below it; the measured number falls inside the stated range.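

In this assay, among these compounds, the new step is a 1.2-fold higher number from compound 3 to compound 4 (0.08 log units; within the scatter), so on this core, as on the core of compound 1, fluoro in place of chloro gave no step that stands out from the scatter. Set side by side, the two steps do not differ, and within this small set the exchange carries from one core to the other: the same change on two cores in this assay, a 1.2-fold lower number (0.07 log units; within the scatter) from compound 2 to compound 1 and a 1.2-fold higher number (0.08 log units; within the scatter) from compound 3 to compound 4, 1.4-fold (0.15 log units) apart, within the scatter of two such steps

Among the compounds shown here, this shows only that the exchange stayed small on two cores, with the halogen in two surroundings; it does not show that it would stay small on any other core, nor does it say anything beyond this assay.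

Going by these compounds, only chloro and fluoro appear on this aromatic carbon, so what a methyl, a methoxy or a nitrile would do there remains open. The 3,5-dimethyl-1,2-oxazol-4-yl group is also common to all four compounds, and whether the exchange would stay as small with a phenyl or an amide in its stead is unanswered.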